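The source may hold more compounds than are shown below. What is called first, only, known or untested is meant among the compounds shown, and "the series" means these compounds.

Compound 1 `COc1cccc([C@@H]2[C@H](Oc3ccccc3)C(=O)N2c2cc(OC)c(OC)c(OC)c2)c1` gives 171000 nM in a functional assay on MCF7 cells (Homo sapiens) for antiproliferative activity, read by MTT assay, with stated times of 24 h and 72 h; a higher number here means a weaker inhibitor, a lower number a stronger inhibitor. Compound 2 `COc1cc(N2C(=O)[C@@H](Oc3ccccc3)[C@H]2c2ccc3ccccc3c2)cc(OC)c1OC` gives 282000 nM. Compound 3 `COc1ccc([C@@H]2[C@H](Oc3ccccc3)C(=O)N2c2cc(OC)c(OC)c(OC)c2)c([N+](=O)[O-])c1O` gives 89000 nM.

Among these three numbers compound 2 stands highest. Its nearest neighbour is compound 1, and that step, a 1.6-fold higher number from compound 1 to compound 2 (0.22 log units; within the scatter), lies within the scatter, so the two cannot be ordered. Its furthest is compound 3, reached by a 3.2-fold lower number from compound 2 to compound 3 (0.50 log units; beyond the scatter), a modest step beyond the scatter.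

Compound 4 `COc1ccc([C@@H]2[C@H](Oc3ccccc3)C(=O)N2c2cc(OC)c(OC)c(OC)c2)c(N)c1O` has not yet been measured. Relative to compound 2 it carries the change (a group of 10 heavy atoms (7 carbon, 1 nitrogen, 2 oxygen; one six-membered aromatic ring of carbon only) in place of a group of 10 heavy atoms (10 carbon; 2 six-membered aromatic rings of carbon only), on a saturated ring carbon). The group that enters resembles the one that enters in the step from compound 2 to compound 3, which gave a 3.2-fold lower number from compound 2 to compound 3 (0.50 log units; beyond the scatter); the related step of a 1.9-fold lower number from compound 1 to compound 3 (0.28 log units; within the scatter) stayed within the scatter. For the measured compounds named here, no measured pair separates compound 3 from compound 4 directly, so the effect of that last difference is unknown.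

On this basis compound 4 is expected to give a number close to that of compound 3, about 100000 nM in this assay, with a range of 40000 nM to 250000 nM. The expected step is therefore a 2.8-fold lower number from compound 2 to compound 4 (0.45 log units; beyond the scatter), a modest lowering of the number beyond the scatter, though the range also allows no change beyond it.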

Compound 4, half-maximal inhibitory concentration: 19000 nM
Beside the measured number, compound 4's estimate is 5.3-fold (0.72 log units) above it; measured number below the stated range.
By their numbers in this assay, from the lowest: compound 4; then compounds 3, 1 and 2 (each within the scatter of the next, the first and the last beyond it).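

The group on this saturated ring carbon, next to the ring nitrogen, can move the number well beyond the scatter: the group in compound 4 gives a 15-fold lower number from compound 2 to compound 4 (1.17 log units; beyond the scatter) and a 9.0-fold lower number from compound 1 to compound 4 (0.95 log units; beyond the scatter), which makes compound 4 the strongest of the four in this assay. For the compounds shown here, the single change of amino in place of nitro on an aromatic carbon gives a 4.7-fold lower number from compound 3 to compound 4 (0.67 log units; beyond the scatter), so the outcome depends on what this aromatic ring carries and not only on the ring being there. No measurement at hand explains the gain from the amino group.

From the compounds shown here alone, compound 4 alone carries the amino group, so it remains open whether this gain would hold without the hydroxyl and methoxy groups on the same ring. The compounds shown also leave open what an acetamide or a dimethylamino group would give in place of amino, and whether the effect would persist with a group other than phenoxy on the ring atom that bears it.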